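The source may hold more compounds than are shown below. What is called first, only, known or untested is meant among the compounds shown, and "the series" means these compounds.

Series notes. Among the compounds with values here, in a functional assay on SK-BR-3 cells (Homo sapiens) for antiproliferative activity, read by MTT assay, with a stated time of 72 h (on this read-out lower numbers stand for stronger inhibition and higher numbers for weaker inhibition), compound 2 `C/C=C1/[C@H](O[C@@H]2O[C@H](CO)[C@@H](O)[C@H](O)[C@H]2O)OC=C(C(=O)OC)[C@H]1CC(=O)OCCC1CCCCC1` gives 2000 nM, the only number in hand. Compound 1 `C/C=C1/[C@H](O[C@@H]2O[C@H](COC(C)=O)[C@@H](OC(C)=O)[C@H](OC(C)=O)[C@H]2OC(C)=O)OC=C(C(=O)OC)[C@H]1CC(=O)OCCC(C)C` returns only a limit, > 15000 nM. This is the limit of > 15000 nM in this assay, at which 1 of the 2 values shown sits. Compound 3 `C/C=C1/[C@H](O[C@@H]2O[C@H](CO)[C@@H](O)[C@H](O)[C@H]2O)OC=C(C(=O)OC)[C@H]1CC(=O)OCCC(C)C` is not yet measured; it differs from compound 2 by isopropyl in place of cyclohexyl on a saturated chain carbon, two bonds along the chain from an oxygen next to a carbonyl group. Within the data shown here, no pair of measured compounds differs in one place, so no measured step is on record. Compound 2 holds its 2000 nM with the larger group. The step expected on that basis, a 2.5-fold higher number from compound 2 to compound 3 (0.40 log units; beyond the scatter), runs toward weaker inhibition, somewhat beyond the usual scatter. Compound 3 is therefore estimated at 5000 nM, between 1500 nM and 15000 nM.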

Compound 3, half-maximal inhibitory concentration: 9020 nM
The estimate for compound 3 lay 1.8-fold (0.26 log units) below the measured number; the range from low to high includes it.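

In this assay, within the data shown here, the change from cyclohexyl to isopropyl gives a 4.5-fold higher number from compound 2 to compound 3 (0.65 log units; beyond the scatter), the first measured step at this position, and it runs toward weaker inhibition. Both compounds return numbers, so this step can be read directly. Compound 1 is the only compound held at a limit: the limit of > 15000 nM in this assay, at which 1 of the 3 values shown sits.

Among these compounds, only two groups at this position can be compared, so the effect of a phenyl ring, a longer chain or a terminal amine remains open. From the compounds shown here alone, whether the step carries over to a core bearing the acetyl groups of compound 1 also remains open.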